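Swapping the Sulfonyl Aryl Group in a Phenylpiperazine Series

The source may report more compounds than this note shows. Statements on the series, on what has been measured and on what is new or still open speak of the compounds shown alone.

Among the measured compounds shown here, compound 2 `O=S(=O)(c1cccc2ccccc12)N(CCCN1CCN(c2ccccc2)CC1)CC1CC1` gives the lowest of the two numbers so far in an assay on CHO cells for displacement of a labelled ligand from 5-hydroxytryptamine receptor 7 (Homo sapiens) (a lower number here means a stronger inhibitor, a higher number a weaker inhibitor), namely 152 nM. Compound 1 `O=S(=O)(c1ccc(C(F)(F)F)cc1)N(CCCN1CCN(c2ccccc2)CC1)CC1CCCCC1` gives 456 nM in this assay, a weaker figure that lies beyond the scatter. Compound 3 `O=S(=O)(c1ccc(C(F)(F)F)cc1)N(CCCN1CCN(c2ccccc2)CC1)CC1CC1` carries 4-(trifluoromethyl)phenyl in place of naphthalen-1-yl on a sulfonyl sulfur. For the measured compounds named here, no measured pair shows this exchange on its own, so the step from compound 2 to compound 3 is expected to be a modest move toward a higher number, likely just beyond the scatter: a 2.3-fold higher number from compound 2 to compound 3 (0.36 log units; beyond the scatter). Compound 3 is thus estimated at 350 nM, within a range of 120 nM to 1000 nM.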

Compound 3, half-maximal inhibitory concentration: 334 nM
The estimate for compound 3 lay 1.0-fold (0.02 log units) above the measured number; low and high end bracket the measured number.
By their numbers in this assay, from the lowest: compound 2; then compounds 3 and 1 (each within the scatter of the next).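

In this assay, 4-(trifluoromethyl)phenyl in place of naphthalen-1-yl on the sulfonyl sulfur gives a 2.2-fold higher number from compound 2 to compound 3 (0.34 log units; beyond the scatter) and so shows, in a single clean exchange, that this position responds to the aryl group. Cyclopropyl in place of cyclohexyl gives a 1.4-fold lower number from compound 1 to compound 3 (0.14 log units; within the scatter) and so leaves the two compounds indistinguishable in this assay. Nothing measured here accounts for either step.

On these data alone, whether naphthalen-2-yl or unsubstituted phenyl on the sulfonyl sulfur would give a lower or higher number stays open. So does whether naphthalen-1-yl keeps its advantage with cyclohexyl in place of cyclopropyl.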